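The source may hold more compounds than are shown below. What is called first, only, known or untested is meant among the compounds shown, and "the series" means these compounds.

Measured so far in a functional assay on MCF7 cells (Homo sapiens) for inhibition, read by MTT assay, with a stated time of 72 h; on this read-out lower numbers stand for stronger inhibition and higher numbers for weaker inhibition:
- compound 1 `Cc1ccc(C(=O)OC2(C(=O)Nc3ccc([N+](=O)[O-])cc3)CCCCC2)cc1`: 9.8 nM
- compound 2 `O=C(OC1(C(=O)Nc2ccc([N+](=O)[O-])cc2)CCCCC1)c1ccc(Cl)cc1`: 15 nM
- compound 3 `Cc1ccccc1C(=O)OC1(C(=O)Nc2ccc([N+](=O)[O-])cc2)CCCCC1`: 516 nM

Compound 3 stands highest of the three numbers in this assay, so it is the weakest inhibitor here: the step of a 53-fold higher number from compound 1 to compound 3 (1.72 log units; beyond the scatter) and the step of a 34-fold higher number from compound 2 to compound 3 (1.54 log units; beyond the scatter) are both large and beyond the scatter, while a 1.5-fold higher number from compound 1 to compound 2 (0.18 log units; within the scatter) stays within it. Compound 4 `O=C(OC1(C(=O)Nc2ccc([N+](=O)[O-])cc2)CCCCC1)C(O)c1ccccc1` is unmeasured. It differs from compound 3 by hydroxy(phenyl)methyl in place of 2-methylphenyl on a carbonyl carbon. Going by the values given here, both large measured steps show that exchanging the group on this carbonyl carbon can move the number a great deal, but no measured step tells what hydroxy(phenyl)methyl does. Compound 4 is therefore expected near 150 nM, somewhere between 15 nM and 1500 nM. That estimate means a step of a 3.4-fold lower number from compound 3 to compound 4 (0.54 log units; beyond the scatter), a cautious move back toward the lower numbers.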

Compound 4, half-maximal inhibitory concentration: 5.01 nM
The estimate for compound 4 lay 30-fold (1.48 log units) above the measured number; measured number outside the range, below it.
By their numbers in this assay, from the lowest: compounds 4, 1 and 2 (each within the scatter of the next, the first and the last beyond it); then compound 3.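

The earlier compounds shown here showed only that swapping one substituted phenyl group for another on this carbonyl carbon could raise the number. Hydroxy(phenyl)methyl shows a different kind of group can bring it far down, with a 100-fold lower number from compound 3 to compound 4 (2.01 log units; beyond the scatter), and it also gives a 3.0-fold lower number from compound 2 to compound 4 (0.48 log units; beyond the scatter) and a 2.0-fold lower number from compound 1 to compound 4 (0.29 log units; within the scatter), so a phenyl ring need not sit directly on this carbonyl carbon for a low number. Nothing available explains why this group behaves as it does. The compounds shown leave open whether the hydroxy or the extra carbon matters more. A plain benzyl group, or an amine in place of the hydroxy, would help separate the two.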